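Working notes on compound 4 and its measured neighbours

The compounds below may be only part of what the source reports. "The series", "measured", "known", "first", "only" and "open" are said of these compounds alone.

Compound 1 `COc1cc(C)c(S(=O)(=O)N(C)CCOCC(=O)N2CCC(C(C)(C)CN(C)C)CC2)c(C)c1` gives 7.5 in a functional assay on Umbilical vein for antagonist activity at B1 bradykinin receptor (Homo sapiens), using Schild analysis, with a stated time of 30 min; on this read-out lower numbers stand for lower potency and higher numbers for higher potency (the scale is a negative logarithm). Compound 2 `COc1cc(C)c(S(=O)(=O)N(C)CCOCC(=O)N2CCC(N3CCN(C(C)C)CC3)CC2)c(C)c1` gives 8.5 in this assay, the highest of the three numbers, while compound 3 `CN(Cc1ccc(C2=NCCN2)cc1)C(=O)COCCN(C)S(=O)(=O)c1ccc(OC(F)(F)F)cc1` gives 7.5. Among the measured compounds shown here, the only single-site step among the measured compounds is a number 1.00 log units higher from compound 1 to compound 2 (beyond the scatter), a change at the same ring position but to a different group. Compound 4 `COc1cc(C)c(S(=O)(=O)N(C)CCOCC(=O)N2CCC(C3CCN(C(C)C)CC3)CC2)c(C)c1` differs from compound 2 by 1-isopropylpiperidin-4-yl in place of 4-isopropylpiperazin-1-yl on a saturated ring carbon. For the measured compounds named here, no measured step removes or alters this group, and compound 3 differs from compound 2 in several places at once, so the measured steps give no direct precedent. The step of a number 0.30 log units lower from compound 2 to compound 4 (within the scatter) is expected to be small. The value of compound 4 in this assay is therefore estimated at 8.2, within 7.5 to 8.9.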

Compound 4, negative logarithm of the antagonist equilibrium constant: 9.3
Estimate against measurement, compound 4: 1.10 log units below, outside the stated range (above it).
By their numbers in this assay, from the lowest: compounds 1 and 3 (each within the scatter of the next); then compound 2; then compound 4.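

Swapping 4-isopropylpiperazin-1-yl for 1-isopropylpiperidin-4-yl keeps the count of heavy atoms and the six-membered ring but replaces one ring nitrogen with carbon, and it gives a number 0.80 log units higher from compound 2 to compound 4 (beyond the scatter) on the same core. The position therefore responds to the ring atoms of the group, not only to its size. Against the open-chain group, the new ring gives a number 1.80 log units higher from compound 1 to compound 4 (beyond the scatter) as the largest step in this set. Nothing available explains the gain.

Open, on these data alone, is whether the isopropyl group on the ring nitrogen contributes, as a methyl group or the free ring amine could show. Also open, as far as these compounds go, is whether an oxygen in place of that ring nitrogen would hold the number.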